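The source may hold more compounds than are shown below. What is called first, only, known or untested is meant among the compounds shown, and "the series" means these compounds.

Within the data shown here, compound 2, `Cc1ccc(-n2nc(-c3ccccc3)nc2CNc2ccc(C(=O)NO)cc2)cc1`, is one of two compounds measured in an assay on Sf9 cells for inhibition of protein deacetylase HDAC6 (Homo sapiens), read by fluorescence, with a stated time of 40 min, tested at 100 nM; on this read-out lower numbers stand for less inhibition and higher numbers for more inhibition at the one concentration tested (going by the name of the read-out). In this assay compound 2 gives 60.7%, which stands at the top of the two numbers shown, and its only neighbour, compound 1, `Cc1ccccc1-n1nc(-c2ccccc2)nc1CNc1ccc(C(=O)NO)cc1`, gives 57.1%. Among the measured compounds shown here, the single measured step, a number 3.6 percentage points higher from compound 1 to compound 2 (within the scatter), lies within the scatter, so the two numbers cannot be told apart. Compound 3, `O=C(NO)c1ccc(NCc2nc(-c3ccccc3)nn2-c2ccc(Br)cc2)cc1`, is not yet measured; it differs from compound 2 by bromo in place of methyl on an aromatic carbon, on an aromatic carbon of a six-membered aromatic ring of carbon only, para to a large group. No measured step exchanges one group for another at that carbon, so nothing shown bears directly on this change, and the one step seen stayed within the scatter. A step of a number 0.7 percentage points lower from compound 2 to compound 3 (within the scatter) is therefore expected for compound 3, nothing beyond the scatter. The estimate for compound 3 in this assay is 60%, between 42% and 78%.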

Compound 3, a percentage reported as inhibition, at one concentration (the size of the read-out at that concentration, not a potency): 65.9%
Estimate against measurement, compound 3: 5.9 percentage points below, and the stated range covers the measured number.
By their numbers in this assay, from the lowest: compounds 1, 2 and 3 (each within the scatter of the next).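

Among these compounds, exchanging methyl for bromo at this carbon, para to a large group, gives a number 5.2 percentage points higher from compound 2 to compound 3 (within the scatter) in this assay and is the first measured exchange of one group for another there; methyl and bromo cannot be told apart in this read-out. The wider change gives a number 8.8 percentage points higher from compound 1 to compound 3 (within the scatter), so 2-methylphenyl and 4-bromophenyl on the aromatic nitrogen cannot be told apart either. No measurement is available here that would explain these numbers.

Going by these compounds, whether an amine, a carboxylic acid or a methoxy group at this carbon would give a step beyond the scatter remains open. Also open, on these data alone, is how 2-bromophenyl on the aromatic nitrogen would compare with 4-bromophenyl, and whether replacing the phenyl group on the other side of the core would matter more.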